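Dimethoxyphenyl versus trimethoxyphenyl on a pyrazolopyrimidine chalcone core

This account rests on a few compounds, and the source may have more. Where it says the series, first, only, none or still open, it means among the compounds named here.

Measured compounds:
compound 1 `COc1ccc(C(=O)/C=C/c2cc(-c3cc(OC)c(OC)c(OC)c3)n3nc(-c4ccccc4)cc3n2)cc1` with 25200 nM
compound 2 `COc1ccc(-c2cc(/C=C/C(=O)c3ccc(C)c(C)c3)nc3cc(-c4ccccc4)nn23)cc1OC` with 12100 nM

In a functional assay on DU-145 cells (Homo sapiens) for antiproliferative activity, read by MTT assay, with a stated time of 24 h (a lower number here means a stronger inhibitor, a higher number a weaker inhibitor), compound 2 gives 12100 nM and holds the lowest of the two numbers. Among the compounds with values here, compound 1 gives 25200 nM, a higher number; the gap between the two is beyond the scatter, though the two differ in more than one place and no single step links them.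

Compound 3 `COc1cc(-c2cc(/C=C/C(=O)c3ccc(C)c(C)c3)nc3cc(-c4ccccc4)nn23)cc(OC)c1OC` follows from compound 2 by one change: methoxy in place of hydrogen on an aromatic carbon. The difference, cut one bond further out, reads dimethoxyphenyl to trimethoxyphenyl. Within the data shown here, no measured pair isolates this change, and compound 1, which also carries a trimethoxyphenyl group, cannot serve as a guide since its other parts differ from compound 2. The step from compound 2 to compound 3 is therefore expected to be small, with no direction beyond the scatter resolved, so a 1.3-fold lower number from compound 2 to compound 3 (0.13 log units; within the scatter) is an estimate. For compound 3 the expected value is 9000 nM, within a range from 3000 nM to 30000 nM.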

Compound 3, half-maximal inhibitory concentration: 15400 nM
For compound 3 the middle estimate is 1.7-fold (0.23 log units) below the measured one; low and high end bracket the measured number.
By their numbers in this assay, from the lowest: compounds 2, 3 and 1 (each within the scatter of the next, the first and the last beyond it).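

In this assay, within the data shown here, the change from 3,4-dimethoxyphenyl to 3,4,5-trimethoxyphenyl reads as a 1.3-fold higher number from compound 2 to compound 3 (0.10 log units; within the scatter) and is the first single-place reading at this ring, so methoxy in place of hydrogen here shows no resolved effect on antiproliferative activity. The carbonyl side can now be read in one place as well: 3,4-dimethylphenyl in place of 4-methoxyphenyl gives a 1.6-fold lower number from compound 1 to compound 3 (0.21 log units; within the scatter) in this assay and so also shows no resolved effect. Nothing at hand bears on the size of either step.

The compounds shown leave open whether a group other than methoxy at this ring position, such as hydroxyl, fluorine or an amine, would shift the number beyond the scatter. They also leave open whether a carboxylic acid or a longer alkoxy chain on the ring at the carbonyl would do so.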